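Enlarging the Amine Substituent in a Serotonin Receptor Agonist Series

The source may hold more compounds than are shown below. What is called first, only, known or untested is meant among the compounds shown, and "the series" means these compounds.

Of the compounds shown here, two of a shared core have been measured. Compound 1 `CC(C)c1nc(C(=O)NCC2(O)CCN(CC3CCOCC3)CC2)c2ccccn12` and compound 2 `CCN1CCC(NC(=O)c2nc(C(C)C)n3ccccc23)CC1` differ only in the group on the amine nitrogen in a ring. In a functional assay on CHO cells for agonist activity at 5-hydroxytryptamine receptor 4 (Homo sapiens), read by a luciferase reporter and cAMP accumulation, with a stated time of 4 h (a lower number here means that less compound is needed, a higher number that more compound is needed for the effect), compound 2 gives 50 nM. In this assay compound 1 gives 56.7 nM, and the gap between the two falls within the usual scatter of repeated measurements, so the two count as equally potent. Compound 3 `COCC(C)(C)CN1CCC(NC(=O)c2nc(C(C)C)n3ccccc23)CC1` has not yet been measured; it differs from compound 2 by 1-(methoxymethyl)-1-methylethyl in place of methyl on a saturated chain carbon bound to an amine nitrogen in a ring. For the measured compounds named here, no measured pair shows this exact change. The expectation rests on compound 1, which already carries a larger group on the ring amine and reaches 56.7 nM. The expected step is a 1.3-fold lower number from compound 2 to compound 3 (0.10 log units; within the scatter), no larger than the usual scatter. The estimate for compound 3 in this assay is 40 nM, between 15 nM and 120 nM.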

Compound 3, half-maximal effective concentration: 47 nM
For compound 3 the middle estimate is 1.2-fold (0.07 log units) below the measured one; the measured number falls inside the stated range.
By their numbers in this assay, from the lowest: compounds 3, 2 and 1 (each within the scatter of the next).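

In this assay, putting 1-(methoxymethyl)-1-methylethyl in place of methyl on a saturated chain carbon bound to an amine nitrogen in a ring gives a 1.1-fold lower number from compound 2 to compound 3 (0.03 log units; within the scatter) and so leaves the two compounds equally potent. This direct pair shows that this place accepts a group of 6 heavy atoms, one of them an oxygen, instead of a single carbon, with the effect staying within the scatter. No measurement here explains this tolerance.

Going by these compounds, how far it extends remains open: an amine, a carboxylic acid or a longer chain at this place might give a similar number or a clearly different one. On these data alone, it is also open how a 2,2-dimethylpropyl group, which lacks the methoxy oxygen, would compare with the 2-(methoxymethyl)-2-methylpropyl group of compound 3.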